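The source may report more compounds than this note shows. Statements on the series, on what has been measured and on what is new or still open speak of the compounds shown alone.

Compound 1 `CCN(CC)Cc1ccc2nc(NC(=O)N/N=C/c3cn(Cc4ccccc4Cl)c4ccccc34)sc2c1`: 980 nM
Compound 2 `CC1CCN(Cc2ccc3nc(NC(=O)N/N=C/c4cn(Cc5ccccc5Cl)c5ccccc45)sc3c2)CC1`: 1080 nM
Compound 3 `CN(C)Cc1ccc2nc(NC(=O)N/N=C/c3cn(Cc4ccccc4Cl)c4ccccc34)sc2c1`: 1600 nM

All three were tested in a functional assay on NCI-H460 cells (Homo sapiens) for cytotoxicity, read by MTT assay, with a stated time of 72 h; on this read-out lower numbers stand for stronger inhibition and higher numbers for weaker inhibition. Compound 1 has the lowest number of the three, but its steps to the others are small: a 1.1-fold higher number from compound 1 to compound 2 (0.04 log units; within the scatter) and a 1.6-fold higher number from compound 1 to compound 3 (0.21 log units; within the scatter), both within the scatter, so the three cannot really be told apart on this read-out.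

Compound 4 `CCN(CC)Cc1ccc2nc(NC(=O)N/N=C/c3cn(Cc4cccc(Cl)c4)c4ccccc34)sc2c1` has not yet been measured. It differs from compound 1 in one place: 3-chlorophenyl in place of 2-chlorophenyl on a saturated chain carbon bound to an aromatic nitrogen. Cut one bond further out, the same change reads as 2-chlorobenzyl to 3-chlorobenzyl.

For the measured compounds named here, none of the measured steps touches this part of the molecule. All three, a 1.1-fold higher number from compound 1 to compound 2 (0.04 log units; within the scatter), a 1.6-fold higher number from compound 1 to compound 3 (0.21 log units; within the scatter) and a 1.5-fold higher number from compound 2 to compound 3 (0.17 log units; within the scatter), exchange the diethylamino, 4-methylpiperidin-1-yl or dimethylamino group on a saturated chain carbon bound to an aromatic carbon, and all stay within the scatter. There is thus no measured guide to the size or direction of the new change. With nothing pointing either way, the expected step is a 1.0-fold higher number from compound 1 to compound 4 (0.01 log units; within the scatter), that is, none beyond the scatter, with a wide range to allow for an untested change. Compound 4 is estimated at 1000 nM in this assay, between 350 nM and 2900 nM.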

Compound 4, half-maximal inhibitory concentration: 220 nM
The estimate for compound 4 lay 4.5-fold (0.66 log units) above the measured number; measured number below the stated range.
By their numbers in this assay, from the lowest: compound 4; then compounds 1, 2 and 3 (each within the scatter of the next).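

In this assay, for the compounds shown here, putting 3-chlorophenyl in place of 2-chlorophenyl on a saturated chain carbon bound to an aromatic nitrogen gives a 4.5-fold lower number from compound 1 to compound 4 (0.65 log units; beyond the scatter), the only step so far that goes beyond the scatter. The groups that leave and enter have the same heavy atoms, the same single aromatic ring and no net charge, so this read-out can distinguish two compounds that differ only in how the same atoms are joined. The exchanges among the diethylamino, 4-methylpiperidin-1-yl and dimethylamino groups could not show this, as all of those steps stayed within the scatter, and nothing measured here bears on the reason for the new step.

The compounds shown leave open whether a benzyl group carrying no chlorine, or 3-bromobenzyl, would give a number closer to compound 4 or to compound 1. They also leave open whether 3-chlorobenzyl would have a similar effect alongside the 4-methylpiperidin-1-yl group of compound 2 or the dimethylamino group of compound 3, so this single step cannot yet be called a general rule for the series.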